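The source may report more compounds than this note shows. Statements on the series, on what has been measured and on what is new or still open speak of the compounds shown alone.

Measured so far in an ADME assay on the whole organism (plasma) for pharmacokinetics, with Rattus norvegicus as the target, at a dose of 2.5 mg/kg by the intravenous route; a lower number here means less compound in the circulation, a higher number more compound in the circulation at the dose given:
- compound 1 `O=C1Nc2c(ccc(F)c2F)C1(c1ccc(O)cc1)c1ccc(F)cc1` at 2530 ng.h/mL
- compound 2 `O=C1Nc2c(ccc(F)c2F)C1(c1ccc(O)cc1)c1cccs1` at 2630 ng.h/mL

Compound 2 stands level with compound 1, within the scatter of this assay. Compound 3 `O=C1Nc2c(ccc(F)c2F)C1(c1ccc(O)cc1)C1CCCC1` carries cyclopentyl in place of thiophen-2-yl on a saturated ring carbon. Within the data shown here, the only measured step, a 1.0-fold higher number from compound 1 to compound 2 (0.02 log units; within the scatter), exchanged one aromatic ring for another and stayed within the scatter. Among the measured compounds shown here, no measured step shows what a non-aromatic ring does here, so the evidence is thin, and no change beyond the scatter is expected. The estimated step is a 1.2-fold lower number from compound 2 to compound 3 (0.08 log units; within the scatter). Compound 3 is expected at 2200 ng.h/mL, within an estimated range of 1000 ng.h/mL to 4800 ng.h/mL.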

Compound 3, area under the concentration-time curve: 2400 ng.h/mL
The estimate for compound 3 lay 1.1-fold (0.04 log units) below the measured number; the measured number falls inside the stated range.
By their numbers in this assay, from the lowest: compounds 3, 1 and 2 (each within the scatter of the next).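

Replacing an aromatic ring with a non-aromatic one at this saturated ring carbon left the exposure unchanged: a 1.1-fold lower number from compound 2 to compound 3 (0.04 log units; within the scatter) and a 1.1-fold lower number from compound 1 to compound 3 (0.02 log units; within the scatter) in this assay. Cyclopentyl, thiophen-2-yl and 4-fluorophenyl are therefore interchangeable at this position in compound 1, compound 2 and compound 3, so aromaticity of the ring is not required to hold this level. Nothing available explains why the exposure holds. All three compounds carry a ring of carbon or of carbon and sulfur here. From the compounds shown here alone, whether an amine, a carboxylic acid or a longer chain at this carbon would move the number beyond the scatter remains open.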